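A few compounds are considered here, and "the series" means these few. Any claim that something is new, unique, unknown or untested is made for them only; others in the source may bear on it.

Measured so far:
- compound 1 `OC[C@H]1O[C@@H](n2cnc3c(NCc4ccccc4Cl)ncnc32)[C@H](O)[C@@H]1O`: 64000 nM
- compound 2 `OC[C@H]1O[C@@H](n2cnc3c(NCc4ccc(F)c(F)c4F)ncnc32)[C@H](O)[C@@H]1O`: > 166000 nM, a limit of the assay and not a number

Among the compounds with values here, in a functional assay on K562 cells (Homo sapiens) for antiproliferative activity, with a stated time of 72 h (on this read-out lower numbers stand for stronger inhibition and higher numbers for weaker inhibition), compound 1 gives 64000 nM, the only true number. Compound 3 `OC[C@H]1O[C@@H](n2cnc3c(NCc4ccccc4OC(F)(F)F)ncnc32)[C@H](O)[C@@H]1O` differs from compound 1 by trifluoromethoxy in place of chloro on an aromatic carbon. Within the data shown here, one measured step bears on this change, though it involves a different substitution on the same aromatic ring: an at least 2.5-fold higher number from compound 1 to compound 2 (0.41 log units; beyond the scatter). With so little evidence, only a small shift is expected, namely a 1.1-fold higher number from compound 1 to compound 3 (0.04 log units; within the scatter), and none beyond the scatter. Compound 3 is estimated at 70000 nM, with an expected range of 25000 nM to 170000 nM.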

Compound 3, half-maximal inhibitory concentration: 81400 nM
The estimate for compound 3 lay 1.2-fold (0.07 log units) below the measured number; the measured number falls inside the stated range.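

In this assay, trifluoromethoxy in place of chloro on this aromatic carbon gives a 1.3-fold higher number from compound 1 to compound 3 (0.10 log units; within the scatter), so the two groups cannot be told apart at this position, and compound 3 yields a true number. Compound 2 remains a limit of the assay and not a number: the limit of > 166000 nM in this assay, at which 1 of the 3 values shown sits.

The compounds shown leave open whether an amine or a carboxylic acid on this aromatic carbon would move the number beyond the scatter. On these data alone, whether a longer chain in place of the saturated chain carbon would do so also stays open.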